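Nitro to cyano: from compound 3 to compound 4

A few compounds are considered here, and "the series" means these few. Any claim that something is new, unique, unknown or untested is made for them only; others in the source may bear on it.

In an ADME assay on L02 cells (Homo sapiens) for cytotoxicity, read by MTT assay, with a stated time of 24 h (a lower number here means a stronger inhibitor, a higher number a weaker inhibitor), compound 1 (`CN1C/C(=C\c2ccncc2)C(=O)/C(=C/c2ccccc2F)C1`) gives 14900 nM. In the same read-out compound 2 (`CN1C/C(=C\c2ccncc2)C(=O)/C(=C/c2ccc(C#N)cc2)C1`) gives 14000 nM. Compound 3 (`O=C1/C(=C/c2cccnc2)CN(S(=O)(=O)c2ccc([N+](=O)[O-])cc2)C/C1=C\c1ccccc1F`) reads > 20000 nM, which is a limit of the assay and not a number. The position of compound 3 is thus (the limit of > 20000 nM in this assay, at which 1 of the 3 values shown sits).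

Compound 4 (`N#Cc1ccc(S(=O)(=O)N2C/C(=C\c3cccnc3)C(=O)/C(=C/c3ccccc3F)C2)cc1`) differs from compound 3 by one change: cyano in place of nitro on an aromatic carbon. In words, this is cyano in place of nitro on an aromatic carbon, para to a large group.

Going by the values given here, no measured step makes this exchange. The nearest is a 1.1-fold lower number from compound 1 to compound 2 (0.03 log units; within the scatter). That step also brings in a cyano group, as 4-cyanophenyl in place of 2-fluorophenyl, but at another place in the structure, so it bears only indirectly. On that evidence, no step beyond the scatter is expected in this assay, and no direction can be favoured. The estimated step is a number no higher from compound 3 to compound 4 (the limit leaves the size open). Compound 4 is expected at 20000 nM, within an estimated range of 11000 nM to 36000 nM.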

Compound 4, half-maximal inhibitory concentration: > 20000 nM
Compound 4: only a limit was reported; the forecaster's own chance of this, stated with the estimate: 50%; the middle value lies on the limit itself.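

Compound 3 and compound 4 each read only as a limit of the assay in this assay, so no step can be read from compound 3 to compound 4: the limit of > 20000 nM in this assay, at which 2 of the 4 values shown sit.

Still open, on these data alone, is whether cyano in place of nitro moves the number in this assay at all, and in which direction.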